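The source may report more compounds than this note shows. Statements on the series, on what has been measured and on what is new or still open speak of the compounds shown alone.

Compound 1 `COc1cc(N2C(N)=C(C#N)C(/C=C/c3ccccc3)C3=C2CC(C)(C)CC3=O)cc(OC)c1OC` gives 30% in a functional assay on Ehrlich cells (Mus musculus) for cytotoxicity, tested at 25 ug/mL; a higher number here means a stronger effect of the compound at the concentration tested, a lower number a weaker effect. Compound 2 `COc1cc(N2C(N)=C(C#N)C(c3ccccc3O)C3=C2CC(C)(C)CC3=O)cc(OC)c1OC` gives 0%. Compound 3 `COc1cc(N2C(N)=C(C#N)C(c3cccc([N+](=O)[O-])c3)C3=C2CC(C)(C)CC3=O)cc(OC)c1OC` gives 20%.

Compound 2 stands lowest of the three: the nearest is compound 3, reached by a number 20 percentage points higher from compound 2 to compound 3 (beyond the scatter), and the furthest is compound 1, from which a number 30 percentage points lower from compound 1 to compound 2 (beyond the scatter). Compound 4 `COc1cc(N2C(N)=C(C#N)C(c3ccc(C)o3)C3=C2CC(C)(C)CC3=O)cc(OC)c1OC` differs from compound 2 by 5-methylfuran-2-yl in place of 2-hydroxyphenyl on a saturated ring carbon. The two steps that bear on this change both swap the group on the same saturated ring carbon, and both of the alternative groups sit above the 2-hydroxyphenyl in this assay, so a modest rise is the more likely direction, though neither step involved a 5-methylfuran-2-yl. Compound 4 is expected to come out at 15%, within 0% to 35%, which amounts to an expected a number 15 percentage points higher from compound 2 to compound 4 (beyond the scatter).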

Compound 4, a percentage reported as activity, at one concentration (the size of the read-out at that concentration, not a potency): 31%
Compound 4: the middle estimate sits 16 percentage points below what was measured; the measured number falls inside the stated range.
By their numbers in this assay, from the lowest: compound 2; then compounds 3, 1 and 4 (each within the scatter of the next, the first and the last beyond it).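

Placing 5-methylfuran-2-yl on this saturated ring carbon in this assay gives a number 31 percentage points higher from compound 2 to compound 4 (beyond the scatter) and also a number 11 percentage points higher from compound 3 to compound 4 (beyond the scatter) in the same swap of groups. A five-membered aromatic ring with one hetero atom therefore holds up here as well as the open-chain 2-phenylethenyl does, with a number 1 percentage points higher from compound 1 to compound 4 (within the scatter) for that exchange. No evidence at hand accounts for these steps.

What the compounds leave open is whether the methyl on the furan contributes, since a plain furan-2-yl does not appear among them. A pyridine ring or a cyclohexyl group at this carbon also remains untested among the compounds shown here.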